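The source may hold more compounds than are shown below. What is called first, only, known or untested is meant among the compounds shown, and "the series" means these compounds.

Measured compounds:
compound 1, `CC(C)c1n[nH]c2c(NCc3ccc(-c4ccccn4)cc3)nc(SC[C@H](O)CN)nc12` — 63 nM
compound 2, `CSCCSc1nc(NCc2ccc(-c3ccccn3)cc2)c2[nH]nc(C(C)C)c2n1` — 975 nM

Among the measured compounds shown here, in a functional assay on HT cells (Homo sapiens) for antiproliferative activity, read by fluorescence, with a stated time of 72 h (a higher number here means a weaker inhibitor of growth, a lower number a stronger inhibitor of growth), compound 2 carries the higher of the two numbers, and the only step in this set, a 15-fold higher number from compound 1 to compound 2 (1.19 log units; beyond the scatter), separates it from compound 1. Compound 3, `C=CCSc1nc(NCc2ccc(-c3ccccn3)cc2)c2[nH]nc(C(C)C)c2n1`, has not been measured. It differs from compound 2 in one place: vinyl in place of (methylsulfanyl)methyl on a saturated chain carbon bound to a sulfur. For the measured compounds named here, the one measured step bears only loosely on this change, since it exchanged the (methylsulfanyl)methyl group for a 2-amino-1-hydroxyethyl group, not for vinyl, and it was large. Going by the values given here, no measured pair shows what the loss of the sulfur from this chain does on its own. For compound 3 the expected step in this assay is therefore a 1.0-fold higher number from compound 2 to compound 3 (0.01 log units; within the scatter), with no change beyond the scatter the most likely outcome. Compound 3 is estimated at 1000 nM, with a range from 300 nM to 3500 nM.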

Compound 3, concentration for 50% growth inhibition: 1010 nM
Estimate against measurement, compound 3: 1.0-fold (0.00 log units) below; low and high end bracket the measured number.
By their numbers in this assay, from the lowest: compound 1; then compounds 2 and 3 (each within the scatter of the next).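

In this assay, the step with vinyl in place of (methylsulfanyl)methyl on a saturated chain carbon bound to a sulfur is a 1.0-fold higher number from compound 2 to compound 3 (0.02 log units; within the scatter), so at this position the loss of the chain's sulfur and its one hydrogen-bond acceptor leaves the number within the scatter. The step with vinyl in place of 2-amino-1-hydroxyethyl is a 16-fold higher number from compound 1 to compound 3 (1.20 log units; beyond the scatter), which matches in size a 15-fold higher number from compound 1 to compound 2 (1.19 log units; beyond the scatter), so two different chains without the amine and hydroxyl both stand well apart from compound 1. No evidence is available to explain these numbers.

On these data alone, what remains open is whether the amine or the hydroxyl of the 2-amino-1-hydroxyethyl group accounts for the gap, which a 2-aminoethyl or a 2-hydroxyethyl chain would separate. As far as these compounds go, how a carboxylic acid or a longer amine chain would behave at this position also remains open.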